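The compounds below may be only part of what the source reports. "The series", "measured", "known", "first", "only" and "open" are said of these compounds alone.

Measured compounds:
compound 1 `CN(CCNCc1cn(-c2ccccc2)nn1)CCNc1ccnc2cc(Cl)ccc12`, 10000 nM
compound 2 `CN(CCNCc1cn(-c2ccnc3cc(Cl)ccc23)nn1)CCNc1ccnc2cc(Cl)ccc12`, 8800 nM
compound 3 `Clc1ccc2c(NCCNCc3cn(-c4ccnc5cc(Cl)ccc45)nn3)ccnc2c1`, 14000 nM

All three numbers were obtained in a functional assay on BXPC-3 cells (Homo sapiens) for antiproliferative activity, read by sulforhodamine B assay, with a stated time of 72 h; on this read-out lower numbers stand for stronger inhibition and higher numbers for weaker inhibition. Compound 3 sits at the upper edge of this small set, but its gaps to compound 1 and to compound 2 both lie within the scatter, so the three compounds cannot be told apart on these numbers. Within the data shown here, the one step between measured compounds that differ in a single place, a 1.1-fold lower number from compound 1 to compound 2 (0.06 log units; within the scatter), also stays within the scatter.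

Compound 4 `CN(CCNc1ccnc2cc(Cl)ccc12)Cc1cn(-c2ccnc3cc(Cl)ccc23)nn1` differs from compound 3 by methyl in place of hydrogen on an amine nitrogen. Among the measured compounds shown here, no measured pair shows this change; the only measured step concerns a different site, the aromatic nitrogen carrying phenyl or 7-chloroquinolin-4-yl, and it was within the scatter. There is therefore nothing in the data that points to a shift in this assay beyond the scatter for the step from compound 3 to compound 4, and the expected step of a 1.3-fold lower number from compound 3 to compound 4 (0.10 log units; within the scatter) is set accordingly. Compound 4 is estimated at 11000 nM in this assay, with a range from 4000 nM to 30000 nM.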

Compound 4, half-maximal inhibitory concentration: 16000 nM
For compound 4 the middle estimate is 1.5-fold (0.16 log units) below the measured one; the measured number falls inside the stated range.
By their numbers in this assay, from the lowest: compounds 2, 1, 3 and 4 (each within the scatter of the next).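

In this assay, the amine nitrogen whose other neighbours are saturated chain carbons now has a measured pair of its own, and methyl in place of hydrogen there gives a 1.1-fold higher number from compound 3 to compound 4 (0.06 log units; within the scatter). Among these compounds, this is the first reading at this position, and it shows that adding this single carbon leaves the number within the scatter. The aromatic nitrogen carrying phenyl or 7-chloroquinolin-4-yl gave the same kind of result earlier, so neither of the two changes read so far has produced a step beyond the scatter. No independent measurement on these compounds speaks to the reason for this result.

The compounds shown leave open whether an ethyl group, an acetyl group or a hydroxyethyl chain on this amine nitrogen would also stay within the scatter, since methyl is the only group compared with hydrogen here. They also leave open whether methyl on one of the other chain amine nitrogens, or a longer chain between the amines, would move the number any further than this single pair did.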